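From Nitrophenyl to Indazolyl on a Shared Amine

A few compounds are considered here, and "the series" means these few. Any claim that something is new, unique, unknown or untested is made for them only; others in the source may bear on it.

Measured so far, in an assay on cells for activation of Cystic fibrosis transmembrane conductance regulator (Homo sapiens), read by fluorescence, with stated times of 10 min and 12 s; a lower number here means that less compound is needed, a higher number that more compound is needed for the effect:
Compound 1, `CCN(CC)c1nc(Nc2cccc(F)c2)nc(OC(C(F)(F)F)C(F)(F)F)n1`, gives 140 nM.
Compound 2, `CCN(CC)c1nc(Nc2cccc(Cl)c2)nc(OC(C(F)(F)F)C(F)(F)F)n1`, gives 2800 nM.
Compound 3, `CCN(CC)c1nc(Nc2ccc([N+](=O)[O-])cc2)nc(OC(C(F)(F)F)C(F)(F)F)n1`, gives 18000 nM.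

Compound 3 needs the most compound of the three, and both gaps to it lie beyond the scatter. The step of a 20-fold higher number from compound 1 to compound 2 (1.30 log units; beyond the scatter) shows that a single halogen swap on the aryl ring already moves the number a long way. The steps of a 130-fold higher number from compound 1 to compound 3 (2.11 log units; beyond the scatter) and a 6.4-fold higher number from compound 2 to compound 3 (0.81 log units; beyond the scatter) show that the aryl group on the ring nitrogen matters even more, with 4-nitrophenyl the least favourable of those tried.

Compound 4, `CCN(CC)c1nc(Nc2ccc3[nH]ncc3c2)nc(OC(C(F)(F)F)C(F)(F)F)n1`, carries a different aryl group there: 1H-indazol-5-yl in place of 4-nitrophenyl on a nitrogen on an aromatic ring. Among the compounds with values here, no measured step covers this exact change, but both aryl swaps seen so far gave lower numbers on leaving 4-nitrophenyl. Compound 4 is therefore expected to show a lower number in this assay, with the step of a 9.0-fold lower number from compound 3 to compound 4 (0.95 log units; beyond the scatter), giving an estimate of 2000 nM, between 300 nM and 12000 nM.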

Compound 4, half-maximal effective concentration: 2800 nM
The estimate for compound 4 lay 1.4-fold (0.15 log units) below the measured number, within the range that was stated.
By their numbers in this assay, from the lowest: compound 1; then compounds 2 and 4 (each within the scatter of the next); then compound 3.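

Swapping 4-nitrophenyl for 1H-indazol-5-yl on this nitrogen gives a 6.4-fold lower number from compound 3 to compound 4 (0.81 log units; beyond the scatter) in this assay so an aryl group with a five-membered aromatic ring and a hydrogen-bond donor is tolerated here. Against 3-chlorophenyl the same swap gives no change at the digits printed from compound 2 to compound 4 (within the scatter) so these two quite different groups cannot be told apart in this assay. The 3-fluorophenyl group still needs the least compound, with a 20-fold higher number from compound 1 to compound 4 (1.30 log units; beyond the scatter) showing that 1H-indazol-5-yl does not reach that level.

Still open, from the compounds shown here alone, is whether the hydrogen on the indazole nitrogen matters, and how an amine or a methoxy group on the phenyl ring would compare with fluoro. Nothing available here accounts for the size of any of these steps.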